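A few compounds are considered here, and "the series" means these few. Any claim that something is new, unique, unknown or untested is made for them only; others in the source may bear on it.

Compounds measured so far:

Compound 1 `O=c1c([C@@H]2C[C@H](c3ccccc3)ON2c2ccccc2)coc2ccc(F)cc12` gives 49000 nM in a functional assay on PC-3 cells (Homo sapiens) for inhibition, read by sulforhodamine B assay, with a stated time of 48 h; on this read-out lower numbers stand for stronger inhibition and higher numbers for weaker inhibition.
Compound 2 `Cc1ccc2occ([C@@H]3C[C@H](c4ccccc4)ON3c3ccccc3)c(=O)c2c1` reaches only the limit of > 60000 nM in this assay, so no number is known for it.
Compound 3 `Cc1ccc2occ([C@@H]3[C@H]4C(=O)N(c5ccccc5)C(=O)[C@H]4ON3c3ccccc3)c(=O)c2c1` gives 11100 nM in this assay.

Of the two numbers shown, compound 3 gives the lowest, and the nearest number, that of compound 1, is higher by more than the usual scatter. Within the data shown here, the only step measured so far is the one from compound 1 to compound 2, a change of a group on an aromatic carbon of the shared core: an at least 1.2-fold higher number from compound 1 to compound 2 (0.08 log units; that floor lies within the scatter). Its size cannot be fixed beyond the floor, since compound 2 sits at the limit of > 60000 nM in this assay, at which 1 of the 3 values shown sits.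

Compound 4 `O=C1[C@H]2[C@H](ON(c3ccccc3)[C@@H]2c2coc3ccc(Br)cc3c2=O)C(=O)N1c1ccccc1` is not yet measured. It differs from compound 3 in one place: bromo in place of methyl on an aromatic carbon. Among the measured compounds shown here, the one measured step on a group at an aromatic carbon of this core stayed within the scatter, so the change to bromo is expected to move the number little, if at all, in this assay. The step from compound 3 to compound 4 is therefore estimated as a 1.0-fold lower number from compound 3 to compound 4 (0.00 log units; within the scatter). Compound 4 is expected to give about 11000 nM in this assay, within a range from 4000 nM to 30000 nM.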

Compound 4, half-maximal inhibitory concentration: 13300 nM
The estimate for compound 4 lay 1.2-fold (0.08 log units) below the measured number; low and high end bracket the measured number.
By their numbers in this assay, from the lowest: compounds 3 and 4 (each within the scatter of the next); then compound 1. At a limit, above all of these: compound 2.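

In this assay, among these compounds, the change from methyl to bromo on this aromatic carbon is the first step at this position with a measured number at both ends: a 1.2-fold higher number from compound 3 to compound 4 (0.08 log units; within the scatter). The earlier change on the same carbon, from fluoro to methyl, gave only a floor, because compound 2 stands at a limit and not at a number: the limit of > 60000 nM in this assay, at which 1 of the 4 values shown sits. Methyl and bromo, each a single heavy atom here, therefore cannot be told apart in this assay on the core shared by compound 3 and compound 4, though this one pair cannot show that the position tolerates every change.

Still open, as far as these compounds go, is whether a group of another kind on this carbon, such as an amine, a carboxylic acid or a longer chain, would move the number beyond the scatter. From the compounds shown here alone, it is also open whether methyl and bromo would stay as close on the core of compound 1, which appears here only with fluoro and methyl.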